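Acetyl in place of the hydroxyethyl chain

The source may report more compounds than this note shows. Statements on the series, on what has been measured and on what is new or still open speak of the compounds shown alone.

compound 1 `CCCn1c(=O)n(C)c(=O)c2c1ncn2CCC(=O)O` — > 100000 nM
compound 2 `CCCn1c(=O)n(C)c(=O)c2c1ncn2CCN(C)C` — > 100000 nM
compound 3 `CCCn1c(=O)n(C)c(=O)c2c1ncn2CCCO` — 22600 nM

In a functional assay (trachea) with Cavia porcellus as the target (a higher number here means that more compound is needed for the effect, a lower number that less compound is needed), compound 3 stands alone with a number; the other two results are limits. Compound 1 sits at the limit of the assay. Compound 2 likewise sits at that limit. The steps of an at least 4.4-fold lower number from compound 1 to compound 3 (0.64 log units; beyond the scatter) and an at least 4.4-fold lower number from compound 2 to compound 3 (0.64 log units; beyond the scatter) both rest on (the limit of > 100000 nM in this assay, at which 2 of the 3 values shown sit), so only their minimum size is known.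

Compound 4 `CCCn1c(=O)n(C)c(=O)c2c1ncn2CC(C)=O` differs from compound 3 by acetyl in place of 2-hydroxyethyl on a saturated chain carbon bound to an aromatic nitrogen. Among the measured compounds shown here, the measured steps show that carboxy and dimethylamino give limits where hydroxymethyl gives a number; no step tests acetyl. Compound 4 is expected to move upward beyond the scatter, a 2.2-fold higher number from compound 3 to compound 4 (0.34 log units; beyond the scatter). The estimate for compound 4 is 50000 nM, between 15000 nM and 150000 nM.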

Compound 4, half-maximal effective concentration: 1900 nM
Compound 4: the middle estimate sits 26-fold (1.42 log units) above what was measured, outside the stated range (below it).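

In this assay, acetyl in place of 2-hydroxyethyl gives a 12-fold lower number from compound 3 to compound 4 (1.08 log units; beyond the scatter), so a group with the same heavy-atom count can still shift the number strongly on this saturated chain carbon bound to an aromatic nitrogen. The steps of an at least 52-fold lower number from compound 1 to compound 4 (1.72 log units; beyond the scatter) and an at least 52-fold lower number from compound 2 to compound 4 (1.72 log units; beyond the scatter) widen the span at this position, but each starts from a limit and gives only a minimum size: the limit of > 100000 nM in this assay, at which 2 of the 4 values shown sit.

The compounds shown do not separate the carbonyl from the lost hydrogen-bond donor as the source of the step. As far as these compounds go, how a methyl ether, an amide or a longer ketone chain would read here remains open.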